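Swapping a Hydroxy for a Propoxy in Compound 2

This account rests on a few compounds, and the source may have more. Where it says the series, first, only, none or still open, it means among the compounds named here.

Among the measured compounds shown here, compound 2 `Cc1cc(O)cc(C)c1-c1cccc(COc2ccc(OCC(=O)O)c(F)c2)c1` is the only compound here with a number: in a functional assay on CHO cells for agonist activity at Free fatty acid receptor 1 (Homo sapiens), read by FLIPR and calcium flux (on this read-out higher numbers stand for an effect only at larger amounts of compound and lower numbers for an effect already at smaller amounts), compound 2 gives 110 nM. Going by these compounds, compound 1 `Cc1cc(OCc2cccc(-c3c(C)cc(OCCCS(C)(=O)=O)cc3C)c2)ccc1N(CC(=O)O)C(=O)c1ccccc1` belongs to the same set, but in this assay compound 1 is reported as "not determined" (no result reported), so its value stays open. Compound 3 `CCCOc1cc(C)c(-c2cccc(COc3ccc(OCC(=O)O)c(F)c3)c2)c(C)c1` is the compound still to be tested. It differs from compound 2 in one place: propyl in place of hydrogen on an oxygen on an aromatic ring. For the measured compounds named here, no step between two measured compounds is known, so there is nothing to lean on for the size of the expected change, and the estimate rests on compound 2 alone. Because compound 2 already gives 110 nM, the expectation is that the propyl ether keeps the activity in the same region, possibly with a small gain. The expected step reads a 1.4-fold lower number from compound 2 to compound 3 (0.14 log units; within the scatter). Compound 3 is therefore estimated at 80 nM, with a range from 25 nM to 300 nM that allows for no change beyond the scatter as well as for a modest improvement.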

Compound 3, half-maximal effective concentration: 106 nM
Compound 3: middle estimate off by 1.3-fold (0.12 log units), on the low side; low and high end bracket the measured number.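

Until now there was a single number for this series, so nothing could be said about what the oxygen on the aromatic ring will accept. In this assay the step reads a 1.0-fold lower number from compound 2 to compound 3 (0.02 log units; within the scatter) and that places the hydroxy and propoxy compounds level, which shows that the hydrogen on this oxygen is not needed to reach this level of activity and that a propyl group, with its 3 carbon atoms, can sit there without a visible penalty. No measurement shown here speaks to why the two compounds read alike.

One step marks only one point at this position, so it does not show how much room there is beyond propyl, or whether a longer chain such as octyl, or a chain ending in an amine, would read the same. Compound 1 also carries a chain on this oxygen, but it differs from the others in more than one place and has no number, so it adds nothing to the question.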